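The source may report more compounds than this note shows. Statements on the series, on what has been measured and on what is new or still open speak of the compounds shown alone.

Values in an assay on isolated protein with Bile acid receptor (Homo sapiens) as the target (a lower number here means that less compound is needed, a higher number that more compound is needed for the effect), for the three measured compounds of the series:

compound 1, `COC(=O)/C=C/c1cccc(N(Cc2ccc(/C=C/c3c(C)cc(C)cc3C)cc2)C(=O)C(C)C)c1`: 149 nM
compound 2, `COC(=O)/C=C/c1cccc(N(Cc2ccc(-c3ccc(SC)cc3)cc2)C(=O)C(C)C)c1`: 51 nM
compound 3, `CCOc1cccc(-c2ccc(CN(C(=O)C(C)C)c3cccc(/C=C/C(=O)OC)c3)cc2)c1`: 173 nM

Compound 3 gives the highest of the three numbers in this assay. Its nearest neighbour is compound 1, with a 1.2-fold higher number from compound 1 to compound 3 (0.06 log units; within the scatter); the gap to compound 2 is larger, with a 3.4-fold higher number from compound 2 to compound 3 (0.53 log units; beyond the scatter). Compound 2 is the only one of the three that stands beyond the scatter from the other two, as seen also in a 2.9-fold lower number from compound 1 to compound 2 (0.47 log units; beyond the scatter).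

The next compound is compound 4, `COC(=O)/C=C/c1cccc(N(Cc2ccc(-c3c(OC)cccc3OC)cc2)C(=O)C(C)C)c1`. It differs from compound 3 in one place: 2,6-dimethoxyphenyl in place of 3-ethoxyphenyl on an aromatic carbon.

For the measured compounds named here, none of the measured steps changes the number of methoxy groups or moves the oxygen substituent on the outer ring, so no step bears directly on this change. What the series does show is that swapping the whole group at this position has moved the numbers in this assay only modestly, from within the scatter (compound 1 to compound 3) to beyond the scatter but still modest (compound 2 to compound 3). On that basis a step of no more than modest size in either direction is expected from compound 3 to compound 4, with the middle of the expectation close to the number of compound 3 itself. The expected step is a 1.2-fold higher number from compound 3 to compound 4 (0.06 log units; within the scatter).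

Compound 4 is therefore estimated at 200 nM in this assay, with an expected range from 70 nM to 600 nM.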

Compound 4, half-maximal effective concentration: 95 nM
Beside the measured number, compound 4's estimate is 2.1-fold (0.32 log units) above it; the measured number falls inside the stated range.
By their numbers in this assay, from the lowest: compounds 2, 4, 1 and 3 (each within the scatter of the next, the first and the last beyond it).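

In this assay the 2,6-dimethoxyphenyl group of compound 4 stands within the scatter of all three earlier groups at this position, para to a large group (a 1.8-fold lower number from compound 3 to compound 4 (0.26 log units; within the scatter); a 1.9-fold higher number from compound 2 to compound 4 (0.27 log units; within the scatter); a 1.6-fold lower number from compound 1 to compound 4 (0.20 log units; within the scatter)). Compounds 2 and 3 lie beyond the scatter of each other, whereas compound 4 cannot be separated from either, so the new value bridges the one gap seen so far instead of adding a new level. Going from one hydrogen-bond acceptor in 3-ethoxyphenyl to two in 2,6-dimethoxyphenyl therefore gives no step beyond the scatter, but no measurement at hand explains this result or any other step in the series.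

Every group shown at this position is neutral and carries an aromatic ring of carbon only, so an amine, a carboxylic acid on that ring or a plain alkyl chain in its place remains open. From the compounds shown here alone, it is also open whether a phenyl ring with a single methoxy group would stand with compound 4 in this assay or whether both methoxy groups are needed for its value.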